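Adding a methyl to the anilino group of compound 1

The compounds below may be only part of what the source reports. "The series", "measured", "known", "first", "only" and "open" are said of these compounds alone.

For the measured compounds named here, in a functional assay on FM3A cells (Mus musculus) for antiproliferative activity, read by cell counting, with a stated time of 2 days (a lower number here means a stronger inhibitor, a higher number a weaker inhibitor), compound 1 (`COc1cc(C(=O)c2sc(Nc3ccccc3)nc2N)cc(OC)c1OC`) gives 23 nM as the only actual number among the three compounds measured so far. Compound 2 (`COc1ccc(C(=O)c2sc(Nc3ccccc3)nc2N)cc1OC`) gives > 10000 nM as a limit of the assay, not a number. Compound 3 (`COc1ccc(C(=O)c2sc(Nc3ccc(Cl)cc3)nc2N)cc1`) gives > 10000 nM as a limit of the assay, not a number.

Going by the values given here, the one measured step of an at least 430-fold higher number from compound 1 to compound 2 (2.63 log units; beyond the scatter) is large and puts hydrogen in place of methoxy on an aromatic carbon. Compound 4 (`COc1cc(C(=O)c2sc(Nc3ccc(C)cc3)nc2N)cc(OC)c1OC`) changes a different part of compound 1 and turns its anilino group into (4-methylphenyl)amino. The difference methyl in place of hydrogen on an aromatic carbon amounts to methyl in place of hydrogen on an aromatic carbon, para to a large group.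

Among the compounds with values here, no measured step changes the anilino group alone, so the large methoxy step offers no direct guide. With compound 1 at 23 nM as the starting point, no shift beyond the scatter is expected in this assay for this small change. The estimated step of a 1.3-fold higher number from compound 1 to compound 4 (0.12 log units; within the scatter) is therefore expected to be small. Compound 4 is estimated at 30 nM with 6 nM to 200 nM as the expected range.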

Compound 4, half-maximal inhibitory concentration: 15 nM
The estimate for compound 4 lay 2.0-fold (0.30 log units) above the measured number, within the range that was stated.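

In this assay the methyl gives a 1.5-fold lower number from compound 1 to compound 4 (0.19 log units; within the scatter), so the two compounds cannot be told apart. For the compounds shown here, this is the first measured change to the anilino group of compound 1 alone, and it shows that a single methyl on this aromatic carbon, para to a large group, leaves the antiproliferative potency in place. That contrasts with the large loss seen when a methoxy group on the other aromatic ring is replaced by hydrogen.

From the compounds shown here alone, one small group at one place says little about how much change the anilino group can take, and whether an ethyl group, a methoxy group or an amine at the same carbon would also keep the potency remains open. Compound 3 carries a chlorine on its anilino group but also differs from compound 1 elsewhere, and its value is a limit, not a number: the limit of > 10000 nM in this assay, at which 2 of the 4 values shown sit.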